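Series notes: from compound 2 to compound 4

This account rests on a few compounds, and the source may have more. Where it says the series, first, only, none or still open, it means among the compounds named here.

Three compounds of the series have a number in an ADME assay on microsomes from liver (Rattus norvegicus) for metabolic stability, with a stated time of 10 min; on this read-out higher numbers stand for a more stable compound and lower numbers for a less stable compound. Compound 1 `CCSc1nn2cc(-c3cc4ccccc4o3)nc2s1` gives 35%. Compound 2 `COc1cc(OCc2cccc(COc3ccccc3)c2)c2cc(-c3cn4nc(OC)sc4n3)oc2c1` gives 64% in this assay. Compound 3 `COc1cc(OCc2ccccc2OCc2ccccc2)c2cc(-c3cn4nc(OC)sc4n3)oc2c1` gives 22% in this assay. Compound 2 therefore stands highest of the three numbers: the nearest is compound 1, whose number lies well below it and beyond the scatter, and the furthest is compound 3, whose number lies further below it still and also beyond the scatter. No pair among these three differs in one place only, so no single step between measured compounds can be read off.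

Compound 4 `COc1cc(OCc2cccc(CCc3ccccc3)c2)c2cc(-c3cn4nc(OC)sc4n3)oc2c1` has not yet been measured in this assay. It differs from compound 2 in one place: benzyl in place of phenoxy on a saturated chain carbon bound to an aromatic carbon. Going by the values given here, no measured step of this kind exists, so the expectation rests on the number of compound 2 alone. The step from compound 2 to compound 4 is estimated to be a moderate decrease, a number 14 percentage points lower from compound 2 to compound 4 (beyond the scatter), although a result within the scatter would not be surprising. Compound 4 is expected to give about 50% in this assay, with a range from 25% to 75%.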

Compound 4, percent of the compound remaining: 68%
Estimate against measurement, compound 4: 18 percentage points below; low and high end bracket the measured number.
By their numbers in this assay, from the lowest: compound 3; then compound 1; then compounds 2 and 4 (each within the scatter of the next).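

In this assay, going by these compounds alone, benzyl in place of phenoxy on a saturated chain carbon bound to an aromatic carbon gives a number 4 percentage points higher from compound 2 to compound 4 (within the scatter), the first step that can be read at a single place. The same difference, read as phenoxymethyl to phenethyl, leaves the number of heavy atoms and the aromatic ring unchanged while removing the oxygen and its hydrogen-bond acceptor, and this exchange does not separate the two compounds on this read-out. The compounds shown offer no independent measurement that could account for this outcome.

Going by these compounds, this conclusion rests on one matched pair, so it is open whether the same lack of separation would hold if the other parts of the molecule were changed. On these data alone, it is also open how this read-out would respond at this place to a group of a different kind, such as a longer chain like phenylpropyl, a tertiary amine like dimethylaminomethyl or a carboxylic acid.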